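The compounds below may be only part of what the source reports. "The series", "measured", "known", "first", "only" and "open" are said of these compounds alone.

Compound 1 `Cc1noc(C)c1-c1cnc(N)c(Oc2ccc(C(=O)Nc3ccc(Cl)cc3)cc2)n1`: 14400 nM
Compound 2 `Cc1noc(C)c1-c1cnc(N)c(Oc2ccc(C(=O)Nc3cccc(Cl)n3)cc2)n1`: 35700 nM
Compound 3 `Cc1noc(C)c1-c1cnc(N)c(Oc2ccc(C(=O)Nc3ncccc3Cl)cc2)n1`: 27200 nM

These three compounds share one core and differ only in the ring attached to the amide nitrogen. In a functional assay on HepG2 cells (Homo sapiens) for inhibition, read by MTT assay, with a stated time of 72 h (on this read-out lower numbers stand for stronger inhibition and higher numbers for weaker inhibition), compound 2 gives the highest of the three numbers; its step to compound 3 is a 1.3-fold lower number from compound 2 to compound 3 (0.12 log units; within the scatter), within the scatter, while the step from compound 1 is a 2.5-fold higher number from compound 1 to compound 2 (0.39 log units; beyond the scatter), beyond it. Compound 4 `Cn1cc(-c2cnc(N)c(Oc3ccc(C(=O)Nc4cccc(Cl)n4)cc3)n2)cn1` keeps the amide ring of compound 2 and changes the other end of the molecule: 1-methyl-1H-pyrazol-4-yl in place of 3,5-dimethyl-1,2-oxazol-4-yl on an aromatic carbon. Going by the values given here, none of the measured steps alters that part of the structure, so the measured steps give no guide to this change. Without a guide, the expected step is a 1.0-fold lower number from compound 2 to compound 4 (0.01 log units; within the scatter), that is, none beyond the scatter. Compound 4 is therefore estimated at 35000 nM, with a range from 12000 nM to 100000 nM.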

Compound 4, half-maximal inhibitory concentration: 44200 nM
The estimate for compound 4 lay 1.3-fold (0.10 log units) below the measured number; the measured number falls inside the stated range.
By their numbers in this assay, from the lowest: compounds 1, 3, 2 and 4 (each within the scatter of the next, the first and the last beyond it).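

Going by these compounds alone, this is the first look at the far end of the molecule, since the earlier compounds varied only the ring on the amide nitrogen. In this assay, placing 1-methyl-1H-pyrazol-4-yl in place of 3,5-dimethyl-1,2-oxazol-4-yl gives a 1.2-fold higher number from compound 2 to compound 4 (0.09 log units; within the scatter), so this exchange of one five-membered aromatic ring for another, para to the amino group, produces no difference beyond the scatter. No measurement shown explains this result.

The compounds shown leave open whether a different kind of group at this position, such as a simple amine or an unsubstituted phenyl ring, would shift the number. They also leave open whether the same exchange would behave alike with the 4-chlorophenyl amide of compound 1.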